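From an aryl urea to a benzamide on a shared core

The source may report more compounds than this note shows. Statements on the series, on what has been measured and on what is new or still open speak of the compounds shown alone.

Going by the values given here, compound 2 `COc1cc(-c2nn(-c3cccc(NC(=O)Nc4ccc(Cl)c(C(F)(F)F)c4)c3)cc2-c2ccncc2)ccc1Cl` gives 2580 nM in a functional assay on SK-MEL-2 cells (Homo sapiens) for inhibition, read by sulforhodamine B assay, with a stated time of 48 h (a higher number here means a weaker inhibitor of growth, a lower number a stronger inhibitor of growth), the higher of the two numbers so far; compound 1 `COc1cc(-c2nn(-c3cccc(NC(=O)Nc4cccc(C(F)(F)F)c4)c3)cc2-c2ccncc2)ccc1Cl` gives 1960 nM, and the step of a 1.3-fold higher number from compound 1 to compound 2 (0.12 log units; within the scatter) stays within the scatter. Compound 3 `COc1cc(-c2nn(-c3cccc(NC(=O)c4ccccc4)c3)cc2-c2ccncc2)ccc1Cl` differs from compound 2 by phenyl in place of (4-chloro-3-(trifluoromethyl)phenyl)amino on a carbonyl carbon. Among the compounds with values here, the only measured step concerns a different position, so no measured step bears directly on this change, and the expectation for compound 3 rests on the change alone. A larger loss than the scatter is expected, the step of a 2.3-fold higher number from compound 2 to compound 3 (0.37 log units; beyond the scatter) being estimated for compound 3. Compound 3 is therefore expected to give 6000 nM, in the range 1500 nM to 25000 nM.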

Compound 3, concentration for total growth inhibition: 4970 nM
Compound 3: middle estimate off by 1.2-fold (0.08 log units), on the high side; low and high end bracket the measured number.
By their numbers in this assay, from the lowest: compounds 1, 2 and 3 (each within the scatter of the next, the first and the last beyond it).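

In this assay, going by these compounds alone, the step of a 1.9-fold higher number from compound 2 to compound 3 (0.28 log units; within the scatter) stays small, while the step of a 2.5-fold higher number from compound 1 to compound 3 (0.40 log units; beyond the scatter) is the first in this set to pass the scatter, and it does so only modestly. Phenyl on the carbonyl carbon thus leaves compound 3 close to compound 2 but not to compound 1, so the size of the change depends on which urea is taken as the reference. Nothing measured here explains either step. Still open, from the compounds shown here alone, is how a benzamide would behave with a chloro or trifluoromethyl group on its phenyl ring. Going by these compounds, an amine or a carboxylic acid on that ring is equally open.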